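Adding a Chlorine to a Compound Held at a Limit

A few compounds are considered here, and "the series" means these few. Any claim that something is new, unique, unknown or untested is made for them only; others in the source may bear on it.

In a functional assay on PC-3 cells (Homo sapiens) for cytotoxicity, read by MTT assay, with a stated time of 72 h (on this read-out lower numbers stand for stronger inhibition and higher numbers for weaker inhibition), compound 1 `CNC(=O)c1cc(Oc2ccc(C3=NNC(c4cccc(Cl)c4Cl)C3)cc2)ccn1` has the entry "not determined" (no result reported), so it offers no number. Compound 2 `CNC(=O)c1cc(Oc2ccc(C3=NN(C(N)=S)C(c4cccc([N+](=O)[O-])c4)C3)cc2)ccn1` reads > 50000 nM, which is a limit of the assay. Compound 3 `CNC(=O)c1cc(Oc2ccc(C3=NN(C(N)=S)C(c4ccc(Cl)cc4)C3)cc2)ccn1` reads > 50000 nM, which is also a limit and not a number. Going by the values given here, the only measured step, a step that the two limits leave unreadable from compound 2 to compound 3, places 4-chlorophenyl where 3-nitrophenyl stood, but it gives no size to build on.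

Compound 4 `CNC(=O)c1cc(Oc2ccc(C3=NN(C(N)=S)C(c4cccc(Cl)c4Cl)C3)cc2)ccn1` carries 2,3-dichlorophenyl in place of the 4-chlorophenyl of compound 3, on the same saturated ring carbon: 2,3-dichlorophenyl in place of 4-chlorophenyl on a saturated ring carbon.

With compound 3 known only through (the limit of > 50000 nM in this assay, at which 2 of the 3 values shown sit), no step beyond the usual scatter of this assay is expected, and no direction can be favoured. The expected change, a number no higher from compound 3 to compound 4 (the limit leaves the size open), is therefore only a rough estimate. Compound 4 is estimated at 50000 nM, with an expected range from 15000 nM to 100000 nM, and it may well be reported only as a limit.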

Compound 4, half-maximal inhibitory concentration: 15900 nM
Beside the measured number, compound 4's estimate is 3.1-fold (0.50 log units) above it, and the stated range covers the measured number.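

In this assay, the aryl group on this saturated ring carbon proves able to shift the read-out, as 2,3-dichlorophenyl in place of 4-chlorophenyl gives an at least 3.1-fold lower number from compound 3 to compound 4 (0.49 log units; beyond the scatter), and the same group in place of 3-nitrophenyl gives an at least 3.1-fold lower number from compound 2 to compound 4 (0.49 log units; beyond the scatter). Going by these compounds alone, compound 4 thus supplies the first real number in this small set, whereas the step between the two compounds with limits cannot be read. Both new steps are minimum sizes, not exact ones, because each starts from a compound held at a limit: the limit of > 50000 nM in this assay, at which 2 of the 4 values shown sit.

As far as these compounds go, whether 3-chlorophenyl, or a phenyl ring carrying an amine or a carboxylic acid, would also lower the number stays open. Also open, from the compounds shown here alone, is what the ring-nitrogen group of compound 4 contributes, as compound 1, which lacks it, offers no result.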